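Adding a Chlorine to Compound 3 Before the Result Is In

The source may hold more compounds than are shown below. What is called first, only, known or untested is meant among the compounds shown, and "the series" means these compounds.

The measured compounds:
compound 1 `CCOC(=O)CN(Cc1ccccc1)c1nc(NCc2cccc(OC)c2)ncc1[N+](=O)[O-]`: 57400 nM
compound 2 `COC(=O)CN(C)c1nc(Nc2ccc(Cl)cc2)ncc1[N+](=O)[O-]`: 60700 nM
compound 3 `CCOC(=O)CNc1nc(Nc2ccccc2)ncc1[N+](=O)[O-]`: > 100000 nM

Three compounds sharing one core were tested in a functional assay on MCF7 cells (Homo sapiens) for antiproliferative activity, read by MTT assay, with a stated time of 48 h; a lower number here means a stronger inhibitor, a higher number a weaker inhibitor. Compound 1 gives 57400 nM. Compound 2 gives 60700 nM, and these two numbers lie within the usual scatter of each other, so no order between them can be read. Compound 3 stands at the limit of > 100000 nM in this assay, at which 1 of the 3 values shown sits. That figure is a limit of the assay and not a measured number, so where compound 3 truly sits is not known.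

Compound 4 `CCOC(=O)CNc1nc(Nc2ccc(Cl)cc2)ncc1[N+](=O)[O-]` is the next compound. It differs from compound 3 in one place: chloro in place of hydrogen on an aromatic carbon. For the measured compounds named here, no measured pair shows this exact change, so there is no step to lean on. Compound 2 carries the same 4-chlorophenyl and gives a measurable number, which hints that the change may bring a modest gain, though the limit for compound 3 leaves its starting point open. The step from compound 3 to compound 4 is expected to be an at least 1.1-fold lower number from compound 3 to compound 4 (0.04 log units; that floor lies within the scatter). Compound 4 is expected to give about 90000 nM, within 40000 nM to 250000 nM.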

Compound 4, half-maximal inhibitory concentration: > 100000 nM
Compound 4: no number, only a limit (the forecaster's own chance of this, stated with the estimate: 50%); at least 1.1-fold (0.04 log units) between middle value and limit.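

In this assay, the chloro on the phenyl of compound 3 does not bring compound 4 down to a measured number, and both compounds give only a limit: the limit of > 100000 nM in this assay, at which 2 of the 4 values shown sit. The step between these two compounds cannot be read, so the chloro could have had a small effect, or none, without it showing here. Exchanging the amino side chain, ((ethoxycarbonyl)methyl)amino in place of ((methoxycarbonyl)methyl)(methyl)amino, gives an at least 1.6-fold higher number from compound 2 to compound 4 (0.21 log units; that floor lies within the scatter), so the 4-chlorophenyl alone does not clearly separate compound 4 from a compound with a measured value.

On these data alone, how far the true values of compound 3 and compound 4 lie beyond the limit remains unknown. As far as these compounds go, it is also open whether bromo or trifluoromethyl in place of the chloro, or a carboxylic acid in place of the ethoxycarbonyl group, would give a measurable number.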